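Working notes: phenyl in place of pyridin-3-yl

A few compounds are considered here, and "the series" means these few. Any claim that something is new, unique, unknown or untested is made for them only; others in the source may bear on it.

- compound 1 `CC(C)Nc1ccc(NC(=O)c2cc(Cl)ccc2O)c(Cl)c1` gives 82700 nM in an ADME assay on A549 cells (Homo sapiens) for cytotoxicity, read by LDH release, with a stated time of 15 h; on this read-out lower numbers stand for higher toxicity in this test and higher numbers for lower toxicity in this test
- compound 2 `O=C(Nc1ccc(NCc2cccnc2)cc1Cl)c1cc(Cl)ccc1O` gives "not determined" (no result reported) in this assay

Compound 2 has no single number, so it holds no place on the scale and cannot be set against compound 1. Compound 3 `O=C(Nc1ccc(NCc2ccccc2)cc1Cl)c1cc(Cl)ccc1O` is still to be measured in this assay and is compared here with compound 2. The structural change is phenyl in place of pyridin-3-yl on a saturated chain carbon bound to a nitrogen on an aromatic ring and it reads in words as phenyl in place of pyridin-3-yl on a saturated chain carbon bound to a nitrogen on an aromatic ring. Among the compounds with values here, no measured step sizes such a change. A step beyond the usual scatter is not expected, in either direction, although the missing number for compound 2 leaves this uncheckable. Within the data shown here, the only numerical reference is compound 1 at 82700 nM in this series. For compound 3 the half-maximal cytotoxic concentration is estimated at 50000 nM with an expected range of 15000 nM to 120000 nM in this test.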

Compound 3, half-maximal cytotoxic concentration: 81300 nM
For compound 3 the middle estimate is 1.6-fold (0.21 log units) below the measured one; low and high end bracket the measured number.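

In this assay the change of benzyl in place of isopropyl on a nitrogen on an aromatic ring gives a 1.0-fold lower number from compound 1 to compound 3 (0.01 log units; within the scatter), so at this nitrogen the two groups cannot be told apart on the half-maximal cytotoxic concentration. Compound 2 has no number, and the step for phenyl in place of pyridin-3-yl cannot be read, which leaves the effect of that ring nitrogen unsized in this test. No supporting data bear on this result.

The compounds shown leave open whether a longer chain such as phenethyl on the same nitrogen would also stay within the scatter of compound 3. Also open, going by these compounds, is how a carboxylic acid or an amine on the benzyl ring would read in this test.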